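Aryl swap on two related cores in a cytotoxicity assay

The compounds below may be only part of what the source reports. "The series", "measured", "known", "first", "only" and "open" are said of these compounds alone.

Measured compounds:
compound 1, `COc1cccc(-c2cc(-c3c(O)c4ccccc4oc3=O)nc(N)c2C#N)c1`, 2380 nM
compound 2, `N#Cc1c(-c2ccc(F)cc2)cc(-c2c(O)c3ccccc3oc2=O)nc1N`, 22300 nM
compound 3, `COc1cccc(-c2cc(-c3c(O)c4ccccc4oc3=O)nc(S)n2)c1`, 10200 nM

In a functional assay on A549 cells (Homo sapiens) for cytotoxicity, read by MTT assay (a lower number here means a stronger inhibitor, a higher number a weaker inhibitor), compound 1 gives 2380 nM, compound 2 gives 22300 nM and compound 3 gives 10200 nM. Compound 3 thus stands second highest of the three, nearest to compound 2 and furthest from compound 1. Compound 1 and compound 2 differ by 4-fluorophenyl in place of 3-methoxyphenyl on an aromatic carbon, and this change made a 9.4-fold higher number from compound 1 to compound 2 (0.97 log units; beyond the scatter). The cores of compound 1 and compound 3 differ as well, but the difference between the two cores is not broken down here.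

Compound 4, `O=c1oc2ccccc2c(O)c1-c1cc(-c2ccc(F)cc2)nc(S)n1`, is not yet measured in this assay. It differs from compound 3 by 4-fluorophenyl in place of 3-methoxyphenyl on an aromatic carbon. This is the same kind of change as that from compound 1 to compound 2, not the same: in compound 3 the place is on a ring with 2 nitrogen, next to the ring nitrogen and meta to a sulfanyl group, whereas in compound 1 it is on a ring with 1 nitrogen, ortho to a cyano group and meta to an amino group.

Compound 4 is expected at 60000 nM, with a likely range from 20000 nM to 200000 nM. The expected step is a 5.9-fold higher number from compound 3 to compound 4 (0.77 log units; beyond the scatter), resting on the earlier step of a 9.4-fold higher number from compound 1 to compound 2 (0.97 log units; beyond the scatter). The surroundings of the change are not the same, and the estimate is therefore kept somewhat smaller than that earlier step.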

Compound 4, half-maximal inhibitory concentration: 21100 nM
Estimate against measurement, compound 4: 2.8-fold (0.45 log units) above, and the stated range covers the measured number.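

In this assay, putting 4-fluorophenyl in place of 3-methoxyphenyl on the second core again moves the number upward, with a 2.1-fold higher number from compound 3 to compound 4 (0.32 log units; beyond the scatter). Within the data shown here, the direction of the change therefore carries over from one core to the other in these two pairs, but its size does not: the same change on two cores in this assay, a 9.4-fold higher number (0.97 log units; beyond the scatter) from compound 1 to compound 2 and a 2.1-fold higher number (0.32 log units; beyond the scatter) from compound 3 to compound 4, 4.5-fold (0.66 log units) apart, beyond the scatter of two such steps With only two pairs, this does not show which difference between the cores goes with the smaller step, nor does it show how the same change would behave on any third core.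

Each swap alters the substituent on the phenyl ring and its place on that ring together, leaving open how much of either step belongs to losing the methoxy group, to gaining the fluorine, or to the shift in place. The compounds shown also leave open how an unsubstituted phenyl or a chlorophenyl would behave on either core, and whether the amino and cyano groups or the sulfanyl group would shift the step if exchanged one at a time.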